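A few compounds are considered here, and "the series" means these few. Any claim that something is new, unique, unknown or untested is made for them only; others in the source may bear on it.

Of the compounds shown here, three sharing one core have been measured in a functional assay on A549 cells (Homo sapiens) for antiproliferative activity, read by MTT assay, with a stated time of 72 h; on this read-out lower numbers stand for stronger inhibition and higher numbers for weaker inhibition. Compound 1 `CCCSc1nc(Cl)c2c(n1)N(Cc1ccccc1)C(C(=O)O)N2` gives 10700 nM and stands lowest of the three numbers. Compound 2 `CCCSc1nc(Cl)c2c(n1)N(CC1CCCCC1)C(C(=O)N1CCN(C)CC1)N2` gives 13200 nM, a value within the scatter of compound 1, so no order can be read between them. Compound 3 `CCCSc1nc(Cl)c2c(n1)N(Cc1ccccc1)C(C(=O)NCCC1=CCc3ccccc31)N2` gives 48800 nM, which lies beyond the scatter from compound 1. Compound 4 `CCCSc1nc(Cl)c2c(n1)N(Cc1ccccc1)C(C(=O)NCC(C)C)N2` is not yet measured; it differs from compound 1 by isobutylamino in place of hydroxy on a carbonyl carbon. Among the measured compounds shown here, no measured pair shows this change directly, and the two other measured compounds fall on both sides of the scatter around compound 1. The step of a 1.4-fold higher number from compound 1 to compound 4 (0.15 log units; within the scatter) is therefore expected to be small, toward a higher number, or none beyond the scatter. Compound 4 is estimated at 15000 nM, between 6000 nM and 40000 nM, in this assay.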

Compound 4, half-maximal inhibitory concentration: 48200 nM
Compound 4: the middle estimate sits 3.2-fold (0.51 log units) below what was measured; the measured number lies above the stated range.
By their numbers in this assay, from the lowest: compounds 1 and 2 (each within the scatter of the next); then compounds 4 and 3 (each within the scatter of the next).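

In this assay the change from carboxy to isobutylcarbamoyl gives a 4.5-fold higher number from compound 1 to compound 4 (0.65 log units; beyond the scatter) and so weakens inhibition. Among the amides, the much smaller group on the chain gives a 1.0-fold lower number from compound 3 to compound 4 (0.01 log units; within the scatter) and leaves no order between the two, so the size of this amide group makes no readable difference here. No measurement shown gives a reason for the step away from the acid.

Still open, on these data alone, is whether a plain primary carboxamide or a methyl ester would behave like compound 1 or like compound 4.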